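A Methyl on the Nitrogen of Compound 1

The compounds below may be only part of what the source reports. "The series", "measured", "known", "first", "only" and "open" are said of these compounds alone.

For the measured compounds named here, compound 1 `O=c1c2ccccc2sn1NCc1ccccc1` gives 19.5 nM in an assay on HeLa cells for inhibition of Monoglyceride lipase (Rattus norvegicus), read by LC-MS, with a stated time of 10 min (a lower number here means a stronger inhibitor, a higher number a weaker inhibitor), the lowest of the three numbers measured so far. Compound 2 `O=C(O)c1ccc(CNn2sc3ccccc3c2=O)cc1` gives 278 nM in this assay, and compound 3 `O=c1c2ccccc2sn1NCc1ccc(-c2ccccc2)cc1` gives 322 nM. Both steps away from compound 1 were large: a 14-fold higher number from compound 1 to compound 2 (1.15 log units; beyond the scatter) and a 17-fold higher number from compound 1 to compound 3 (1.22 log units; beyond the scatter). Compound 2 and compound 3 sit within the scatter of each other, a 1.2-fold higher number from compound 2 to compound 3 (0.06 log units; within the scatter).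

Compound 4 `CN(Cc1ccccc1)n1sc2ccccc2c1=O` differs from compound 1 by one change: methyl in place of hydrogen on a nitrogen on an aromatic ring. In compound 1 that nitrogen carries a hydrogen; in compound 4 it carries a methyl instead. Going by the values given here, none of the measured steps touches this nitrogen; both replace a hydrogen on an aromatic carbon elsewhere in the molecule, so they bear on the new change only indirectly. They do show that the number rose steeply each time compound 1 was enlarged, whereas the methyl entering here is a group of one carbon, far less than a carboxy or a phenyl. A moderate rise in the number is therefore expected, a 3.1-fold higher number from compound 1 to compound 4 (0.49 log units; beyond the scatter), smaller than the two measured steps. Compound 4 is estimated at 60 nM in this assay, with a range from 15 nM to 300 nM.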

Compound 4, half-maximal inhibitory concentration: 189 nM
For compound 4 the middle estimate is 3.2-fold (0.50 log units) below the measured one; the range from low to high includes it.
By their numbers in this assay, from the lowest: compound 1; then compounds 4, 2 and 3 (each within the scatter of the next).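

In this assay, putting methyl in place of the hydrogen on this nitrogen gives a 9.7-fold higher number from compound 1 to compound 4 (0.99 log units; beyond the scatter) and so moves the number beyond the scatter. For the compounds shown here, the earlier steps changed only aromatic carbons, so this is the first sign that the nitrogen on an aromatic ring is also a place where the number responds to a change. The entering group has just one carbon, which shows that even the addition of a single heavy atom at this nitrogen is enough to produce a clear change. Nothing available explains why the methyl has this effect.

The compounds shown leave open whether an ethyl group or a longer chain on this nitrogen would raise the number further, and whether an acetyl group there would behave as the methyl does. Going by these compounds alone, they also leave open how methyl on this nitrogen would combine with a carboxy or phenyl group on the aromatic carbon changed in the earlier steps.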